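Swapping the amide aryl group on a benzothiazole bis-amide

This account rests on a few compounds, and the source may have more. Where it says the series, first, only, none or still open, it means among the compounds named here.

Compound 1, `Cc1cc(C)cc(C(=O)Nc2nc3ccc(NC(=O)CSc4ccc(Cl)cc4)cc3s2)c1`: > 100000 nM in a functional assay on U2OS cells (Homo sapiens) for antiproliferative activity, read by MTT assay, with a stated time of 72 h; on this read-out lower numbers stand for stronger inhibition and higher numbers for weaker inhibition
Compound 2, `O=C(CSc1ccc(Cl)cc1)Nc1ccc2nc(NC(=O)c3ccc(C(F)(F)F)cc3)sc2c1`: 2890 nM
Compound 3, `Cc1cc(C)cc(C(=O)Nc2nc3ccc(NC(=O)CSc4cccc(O)c4)cc3s2)c1`: 2820 nM

The value for compound 1 is a limit of this assay and not a number. Compound 2 and compound 3 each carry one change relative to compound 1. From compound 1 to compound 2 the change is 4-(trifluoromethyl)phenyl in place of 3,5-dimethylphenyl on a carbonyl carbon, and the step is an at least 34-fold lower number from compound 1 to compound 2 (1.53 log units; beyond the scatter). From compound 1 to compound 3 the change is 3-hydroxyphenyl in place of 4-chlorophenyl on a sulfur, and the step is an at least 35-fold lower number from compound 1 to compound 3 (1.54 log units; beyond the scatter). Compound 2 and compound 3 sit within the scatter of each other.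

Compound 4, `O=C(CSc1cccc(O)c1)Nc1ccc2nc(NC(=O)c3ccc(C(F)(F)F)cc3)sc2c1`, has not yet been measured. It differs from compound 3 by 4-(trifluoromethyl)phenyl in place of 3,5-dimethylphenyl on a carbonyl carbon, the same change that turns compound 1 into compound 2, made on the same kind of place. The two cores differ by 3-hydroxyphenyl in place of 4-chlorophenyl on a sulfur. Since the earlier step started from a limit, its true size is not known, so only a moderate expectation can be placed on it. Compound 4 is expected to give a step of a 4.7-fold lower number from compound 3 to compound 4 (0.67 log units; beyond the scatter) in this assay. The estimate for compound 4 is 600 nM, with a range from 150 nM to 2500 nM.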

Compound 4, half-maximal inhibitory concentration: 630 nM
Compound 4: middle estimate off by 1.1-fold (0.02 log units), on the low side; the measured number falls inside the stated range.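

The 4-(trifluoromethyl)phenyl change again lowers the number in this assay, with a 4.5-fold lower number from compound 3 to compound 4 (0.65 log units; beyond the scatter), but it does not keep its size on the second core: the same change on two cores in this assay, an at least 34-fold lower number (1.53 log units; beyond the scatter) from compound 1 to compound 2 and a 4.5-fold lower number (0.65 log units; beyond the scatter) from compound 3 to compound 4, at least 7.7-fold (0.88 log units) apart, beyond the scatter of two such steps

The 3-hydroxyphenyl change behaves in the same way, with a 4.6-fold lower number from compound 2 to compound 4 (0.66 log units; beyond the scatter), and its size does not carry over either: the same change on two cores in this assay, an at least 35-fold lower number (1.54 log units; beyond the scatter) from compound 1 to compound 3 and a 4.6-fold lower number (0.66 log units; beyond the scatter) from compound 2 to compound 4, at least 7.7-fold (0.88 log units) apart, beyond the scatter of two such steps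

Compound 1 gives a limit and not a number, so both earlier steps have a floor but no known size, and the set shows that the direction carried over on these cores without showing how large either step truly is: the limit of > 100000 nM in this assay, at which 1 of the 4 values shown sits.

The compounds shown vary only the aryl group on the carbonyl carbon and the aryl group on the sulfur, so it remains open whether the direction holds on any further core. Also open, going by these compounds, is how an amine or a carboxylic acid in place of the hydroxyl of compound 4 would read, or a longer chain in place of the one carrying the sulfur.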